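Cytotoxicity limits and the step to compound 4

The compounds below may be only part of what the source reports. "The series", "measured", "known", "first", "only" and "open" are said of these compounds alone.

- Compound 1 `CCN1C(=O)N(c2cccc(OC)c2)C(=O)N(c2ccccc2)c2cc(C(F)(F)F)ccc21`: > 20000 nM (a limit)
- Compound 2 `CCN1C(=O)N(c2ccc(OC)cc2)C(=O)N(c2ccccc2)c2cc(C(F)(F)F)ccc21`: > 16000 nM (a limit)
- Compound 3 `CCN1C(=O)N(c2ccc(C)cc2)C(=O)N(c2ccccc2)c2cc(C(F)(F)F)ccc21`: > 6500 nM (a limit)

All three readings in an ADME assay on C8166 cells (Homo sapiens) for cytotoxicity (a lower number here means that less compound is tolerated, a higher number that more compound is tolerated), are limits and not numbers. Compound 3 stands only at its limit of > 6500 nM in this series. The other two compounds are likewise known only by limits, so the three cannot be ranked.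

Compound 4 `CCN1C(=O)N(c2cccc(C(=O)NC)c2)C(=O)N(c2ccccc2)c2cc(C(F)(F)F)ccc21` differs from compound 3 at one place: 3-(methylcarbamoyl)phenyl in place of 4-methylphenyl on an amide-type nitrogen in a ring. Here 3-(methylcarbamoyl)phenyl takes the place of 4-methylphenyl on an amide-type nitrogen in a ring.

Among the compounds with values here, three measured steps bear on this change: a step that the two limits leave unreadable from compound 1 to compound 2, a step that the two limits leave unreadable from compound 1 to compound 3 and a step that the two limits leave unreadable from compound 2 to compound 3. Within the data shown here, none has a readable size, so none gives a size to carry over, and no measured compound carries the entering group. What they do show is that all three groups tried at this place ended in a limit.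

The reference for the estimate is compound 1, with its limit of > 20000 nM in this assay. Compound 2 supports it with its limit of > 16000 nM in the same assay.

The expected change is a step that the limit leaves unreadable from compound 3 to compound 4, an estimate read against a limit and therefore loose in size. For compound 4 the estimate is 20000 nM, with an expected range from 7000 nM to 60000 nM and a good chance that only a limit is reported.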

Compound 4, half-maximal cytotoxic concentration: > 22000 nM
Compound 4: only a limit was reported; the forecaster's own chance of this, stated with the estimate: 80%; at least 1.1-fold (0.04 log units) between middle value and limit.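

In this assay, compound 4 gives > 22000 nM, which is a limit. Within the data shown here, compound 1, compound 2 and compound 3 are also known only by limits, so no step to compound 4 can be read. The compounds shown leave open at what concentration any of the four becomes cytotoxic, and whether the group on the amide-type nitrogen in a ring changes that concentration.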